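Changing the Aryl Group on the Triazole Nitrogen

This account rests on a few compounds, and the source may have more. Where it says the series, first, only, none or still open, it means among the compounds named here.

Going by the values given here, compound 2 `N#CC1=C(N)Oc2c(N)cc3nc4ccccc4nc3c2C12C(=O)N(Cc1cnnn1-c1cccc(C(F)(F)F)c1)c1ccccc12` is the only compound here with a number rather than a limit: in a functional assay on HCT-116 cells (Homo sapiens) for antiproliferative activity, read by MTT assay, with a stated time of 48 h (a lower number here means a stronger inhibitor, a higher number a weaker inhibitor), compound 2 gives 18900 nM. Compound 1 `Cc1cccc(-n2nncc2CN2C(=O)C3(C(C#N)=C(N)Oc4c(N)cc5nc6ccccc6nc5c43)c3ccccc32)c1` sits at a limit of the assay; in this assay compound 1 gives > 50000 nM, which is a limit, not a number, as the limit of > 50000 nM in this assay, at which 1 of the 2 values shown sits, states. Among the compounds with values here, the one measured step is an at least 2.6-fold lower number from compound 1 to compound 2 (0.42 log units; beyond the scatter), from a methyl to a trifluoromethyl on the phenyl ring attached to the triazole. Compound 3 `COc1ccccc1-n1nncc1CN1C(=O)C2(C(C#N)=C(N)Oc3c(N)cc4nc5ccccc5nc4c32)c2ccccc21` now changes that same phenyl ring in another way: 2-methoxyphenyl in place of 3-(trifluoromethyl)phenyl on an aromatic nitrogen. This removes the trifluoromethyl that accompanied the stronger number of compound 2, and the measured step offers no guidance on methoxy. Compound 3 is therefore expected to give 35000 nM in this assay, within 12000 nM to 100000 nM, which means an expected step of a 1.9-fold higher number from compound 2 to compound 3 (0.27 log units; within the scatter), with a real chance that only a limit is reported.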

Compound 3, half-maximal inhibitory concentration: > 50000 nM
Compound 3: a limit, no number; the forecaster's own chance of this, stated with the estimate: 40%; middle value at least 1.4-fold (0.15 log units) away from the limit.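

Putting 2-methoxyphenyl in place of 3-(trifluoromethyl)phenyl on the aromatic nitrogen brings an at least 2.6-fold higher number from compound 2 to compound 3 (0.42 log units; beyond the scatter), so a second replacement of that aryl group in this assay also ends at a limit rather than a number. Going by these compounds alone, compound 2 therefore remains the only compound with a measurable value, and the step from compound 1 to compound 3 cannot be read, as both values are limits. Neither the methyl nor the methoxy version gives a number: the limit of > 50000 nM in this assay, at which 2 of the 3 values shown sit.

The compounds shown cannot separate the identity of the group from its place on the phenyl ring, as the methoxy and trifluoromethyl groups differ in both. Going by these compounds, it also remains open how a phenyl ring carrying a chlorine atom, an amine or a carboxylic acid would behave at this position.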